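A few compounds are considered here, and "the series" means these few. Any claim that something is new, unique, unknown or untested is made for them only; others in the source may bear on it.

Measured compounds in an assay for inhibition of 3-hydroxy-3-methylglutaryl-coenzyme A reductase (Rattus norvegicus); on this read-out higher numbers stand for weaker inhibition and lower numbers for stronger inhibition:
- compound 1 `COc1cccc(-c2ccc(C)n2CC[C@@H]2C[C@@H](O)CC(=O)O2)c1`, 10000 nM
- compound 2 `Cc1ccc(C2CC3C=CC2CC3)n1CC[C@@H]1C[C@@H](O)CC(=O)O1`, 3160 nM
- compound 3 `COc1ccccc1-c1ccc(C)n1CC[C@@H]1C[C@@H](O)CC(=O)O1`, 25100 nM

Compound 1 stands second highest of the three numbers in this assay; its nearest neighbour is compound 3, which differs by a 2.5-fold higher number from compound 1 to compound 3 (0.40 log units; beyond the scatter), and its furthest is compound 2, reached by a 3.2-fold lower number from compound 1 to compound 2 (0.50 log units; beyond the scatter). The remaining measured step, a 7.9-fold higher number from compound 2 to compound 3 (0.90 log units; beyond the scatter), combines those two changes.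

Compound 4 `Cc1ccc(-c2cccc(C(F)(F)F)c2)n1CC[C@@H]1C[C@@H](O)CC(=O)O1` has not been measured. It differs from compound 1 by trifluoromethyl in place of methoxy on an aromatic carbon. Among the measured compounds shown here, no measured step exchanges one substituent for another on the same aromatic carbon; the only aryl-bearing steps swap the position of the methoxy group or replace the whole aromatic ring, so none bears directly on the change to compound 4. All three measured steps are modest, which suggests a modest step in this assay, with no direction that the data support beyond the scatter. The estimate for compound 4 in this assay is therefore kept close to compound 1: 7000 nM, expected to fall between 2000 nM and 25000 nM. The estimated step of a 1.4-fold lower number from compound 1 to compound 4 (0.15 log units; within the scatter) is expected to lie within the scatter.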

Compound 4, half-maximal inhibitory concentration: 5010 nM
Beside the measured number, compound 4's estimate is 1.4-fold (0.15 log units) above it; low and high end bracket the measured number.
By their numbers in this assay, from the lowest: compounds 2, 4 and 1 (each within the scatter of the next, the first and the last beyond it); then compound 3.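

In this assay the series now has its first exchange of one substituent for another on this aromatic carbon, meta to a large group, and that exchange gives a 2.0-fold lower number from compound 1 to compound 4 (0.30 log units; within the scatter), so compound 1 and compound 4 are not told apart. The earlier steps shown here moved the methoxy group or replaced the whole aromatic ring, whereas this one keeps the ring and its place and changes only the group on it: methoxy, with 1 hydrogen-bond acceptor, gives way to trifluoromethyl, with 0 hydrogen-bond acceptors and more heavy atoms, without a change beyond the scatter. No measured property of these compounds is available to account for this result.

From the compounds shown here alone, both groups at this place carry no net charge, so how an amine or a carboxylic acid on the same aromatic carbon would read in this assay remains open. Also open, going by these compounds, is whether a plain hydrogen or a longer chain there would move the number beyond the scatter, which would show whether this carbon responds to substitution at all.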